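Working notes on a small paw-edema series

A few compounds are considered here, and "the series" means these few. Any claim that something is new, unique, unknown or untested is made for them only; others in the source may bear on it.

Compound 1 `NS(=O)(=O)c1sc(Cl)cc1-c1csc(-c2ccccc2COc2ccc(Cl)cc2)n1` gives, in a functional assay on the whole organism (strain Wistar albino) for inhibition, with Rattus norvegicus as the target, read by paw edema, at a dose of 10 mg/kg by the oral route (a lower number here means less inhibition, a higher number more inhibition at the dose given (going by the name of the read-out)), 76.4%. Compound 2 `Clc1ccc(OCc2csc(-c3ccccc3COc3ccc(Cl)cc3)n2)cc1` gives 76.4% in this assay, and compound 3 `Cc1cccc(OCc2ccccc2-c2nc(-c3cc(Cl)sc3S(N)(=O)=O)cs2)c1` gives 66.8% there. The change (4-chlorophenoxy)methyl in place of 5-chloro-2-sulfamoylthiophen-3-yl on an aromatic carbon gave the step of no change at the digits printed from compound 1 to compound 2 (within the scatter). The cores of compound 1 and compound 3 differ by 3-methylphenyl in place of 4-chlorophenyl on an oxygen on a saturated carbon, with the step of a number 9.6 percentage points lower from compound 1 to compound 3 (within the scatter). Compound 4 `Cc1cccc(OCc2ccccc2-c2nc(COc3ccc(Cl)cc3)cs2)c1` is unmeasured; it differs from compound 3 by (4-chlorophenoxy)methyl in place of 5-chloro-2-sulfamoylthiophen-3-yl on an aromatic carbon, the same change as from compound 1 to compound 2, since the two place descriptions read alike word for word. For compound 4 the expected step is a number 0.8 percentage points lower from compound 3 to compound 4 (within the scatter), resting on the earlier step of no change at the digits printed from compound 1 to compound 2 (within the scatter), which lay within the scatter. Compound 4 is therefore estimated at 66%, with a likely range from 54% to 78%.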

Compound 4, a percentage reported as inhibition, in the whole organism at one dose (the size of the read-out at that dose, not a potency): 67.7%
The estimate for compound 4 lay 1.7 percentage points below the measured number; the range from low to high includes it.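

In this assay the change to (4-chlorophenoxy)methyl in place of 5-chloro-2-sulfamoylthiophen-3-yl gave a number 0.9 percentage points higher from compound 3 to compound 4 (within the scatter) and reads alike on both cores: the same change on two cores in this assay, no change at the digits printed (within the scatter) from compound 1 to compound 2 and a number 0.9 percentage points higher (within the scatter) from compound 3 to compound 4, 0.9 percentage points apart, within the scatter of two such steps.
The change to 3-methylphenyl in place of 4-chlorophenyl gave a number 8.7 percentage points lower from compound 2 to compound 4 (within the scatter) and also reads alike on both cores: the same change on two cores in this assay, a number 9.6 percentage points lower (within the scatter) from compound 1 to compound 3 and a number 8.7 percentage points lower (within the scatter) from compound 2 to compound 4, 0.9 percentage points apart, within the scatter of two such steps.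
These steps carry over between these two cores only within the scatter at a single dose, which shows no measurable dependence on the core here but does not show that either change has a real effect or that either would transfer to a further core.

From the compounds shown here alone, what an amine or a carboxylic acid would give on that aromatic carbon remains open. Also open, going by these compounds, is whether a longer chain in place of the methyl of the 3-methylphenyl group would leave the read-out unchanged.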